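This account rests on a few compounds, and the source may have more. Where it says the series, first, only, none or still open, it means among the compounds named here.

Measured so far in a functional assay on MCF7 cells (Homo sapiens) for cytotoxicity, read by MTT assay, with a stated time of 72 h; a lower number here means a stronger inhibitor, a higher number a weaker inhibitor:
compound 1 `COc1cc2ncnc(Nc3ccc(F)c(Cl)c3)c2cc1NC(=O)N/N=C/c1ccc([N+](=O)[O-])cc1` gives 36800 nM
compound 2 `COc1cc2ncnc(Nc3ccc(F)c(Cl)c3)c2cc1NC(=O)N/N=C/c1cccc(Cl)c1Cl` gives 28700 nM

Compound 2 at 28700 nM sits within the scatter of compound 1, so the two cannot be told apart. Among the compounds with values here, the one measured step is a 1.3-fold lower number from compound 1 to compound 2 (0.11 log units; within the scatter) and it swapped one substituted phenyl for another at the same place.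

Compound 3 `COc1cc2ncnc(Nc3ccc(F)c(Cl)c3)c2cc1NC(=O)N/N=C/c1ccc(O)cc1O` carries 2,4-dihydroxyphenyl in place of 2,3-dichlorophenyl on a carbon with a double bond to nitrogen. Within the data shown here, no measured compound carries this new group, so that single step is only a weak guide. Even so, no step beyond the scatter is expected in this assay for this change. The expected step is a 1.0-fold lower number from compound 2 to compound 3 (0.01 log units; within the scatter) and it remains an estimate. Compound 3 is estimated at 28000 nM with an expected range from 11000 nM to 70000 nM for its measurement.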

Compound 3, half-maximal inhibitory concentration: 36200 nM
For compound 3 the middle estimate is 1.3-fold (0.11 log units) below the measured one; the measured number falls inside the stated range.
By their numbers in this assay, from the lowest: compounds 2, 3 and 1 (each within the scatter of the next).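

In this assay, putting 2,4-dihydroxyphenyl in place of 2,3-dichlorophenyl gives a 1.3-fold higher number from compound 2 to compound 3 (0.10 log units; within the scatter) and putting it in place of 4-nitrophenyl gives a 1.0-fold lower number from compound 1 to compound 3 (0.01 log units; within the scatter). This time the change goes beyond one set of ring substituents to another of the same kind: oxygen replaces chlorine and the entering group brings hydrogen-bond donors and acceptors, yet all three compounds still cannot be told apart on a carbon with a double bond to nitrogen. Nothing available explains this lack of separation.

Still open, on these data alone, is whether any group at this place can move the number beyond the scatter. All three compounds carry a substituted phenyl there, so a phenyl bearing a carboxylic acid or an amine, or a longer alkyl chain in place of the phenyl, would be a different kind of test.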